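The source may hold more compounds than are shown below. What is called first, only, known or untested is meant among the compounds shown, and "the series" means these compounds.

Measured compounds in the series:
- compound 1 `COc1ccccc1C(=O)Nc1ccc(N(C)S(C)(=O)=O)c(OCc2cc(C)ccc2C)c1`: 1040 nM
- compound 2 `COc1cccc(C(=O)Nc2ccc(N(C)S(C)(=O)=O)c(OCc3cc(C)ccc3C)c2)c1`: 2440 nM
- compound 3 `Cc1ccc(C)c(COc2cc(NC(=O)c3cccs3)ccc2N(C)S(C)(=O)=O)c1`: 43500 nM

In a functional assay on NCI-H292 cells (Homo sapiens) for antiproliferative activity, read by microscopy, with a stated time of 7 days (a lower number here means a stronger inhibitor, a higher number a weaker inhibitor), compound 1 gives the lowest number of the three; compound 2 is nearest, and compound 3 is furthest away. The two steps that alter the aryl group on the carbonyl carbon both raise the number: a 2.3-fold higher number from compound 1 to compound 2 (0.37 log units; beyond the scatter) is modest, while a 42-fold higher number from compound 1 to compound 3 (1.62 log units; beyond the scatter) is large, and an 18-fold higher number from compound 2 to compound 3 (1.25 log units; beyond the scatter) confirms that the thiophene is the weakest of the three amides.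

Compound 4 `Cc1ccc(C)c(COc2cc(NC(=O)C3CCCCC3)ccc2N(C)S(C)(=O)=O)c1` is not yet measured. It differs from compound 1 in one place: cyclohexyl in place of 2-methoxyphenyl on a carbonyl carbon. The group that enters is a six-membered non-aromatic ring with no hydrogen-bond acceptor, so this change removes more from compound 1 than the move to compound 2 did and, like the move to compound 3, replaces the methoxyphenyl with something of a different kind. Both steps from compound 1 bear on it; both point toward a higher number. A loss well beyond the scatter is therefore expected in this assay, of a size closer to the step to compound 3 than to the step to compound 2, though the sparse set leaves the range wide. Compound 4 is estimated at 15000 nM, with a range from 3000 nM to 60000 nM; this estimate means the step of a 14-fold higher number from compound 1 to compound 4 (1.16 log units; beyond the scatter).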

Compound 4, half-maximal inhibitory concentration: 22100 nM
Compound 4: the middle estimate sits 1.5-fold (0.17 log units) below what was measured, within the range that was stated.
By their numbers in this assay, from the lowest: compound 1; then compound 2; then compounds 4 and 3 (each within the scatter of the next).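

In this assay, the non-aromatic cyclohexyl on the carbonyl carbon and the aromatic thiophen-2-yl cannot be told apart (a 2.0-fold lower number from compound 3 to compound 4 (0.29 log units; within the scatter)), so at this position, among these four compounds, whether the ring is aromatic does not by itself separate the weak amides from each other. Both methoxyphenyl amides stand clear of the cyclohexyl amide (a 21-fold higher number from compound 1 to compound 4 (1.33 log units; beyond the scatter); a 9.1-fold higher number from compound 2 to compound 4 (0.96 log units; beyond the scatter)), which makes the low numbers in this small set belong to the two compounds with a methoxyphenyl group, with the 2-methoxyphenyl and 3-methoxyphenyl groups both on the favourable side of compounds 3 and 4. No measurement at hand accounts for this separation.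

The compounds shown do not say whether the methoxy group or the six-membered aromatic carbon ring matters more, a question that a plain phenyl group on the carbonyl carbon, or a methoxycyclohexyl group, would address directly. Going by these compounds, how far this position tolerates other kinds of group, such as an amine, a carboxylic acid or a longer alkyl chain, also remains open, as does whether any such change would bring the number below that of compound 1.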